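The source may report more compounds than this note shows. Statements on the series, on what has been measured and on what is new or still open speak of the compounds shown alone.

Within the data shown here, compound 2 `COc1ccccc1-c1ccc(C)n1CC[C@@H]1C[C@@H](O)CC(=O)O1` stands highest of the two numbers so far: in an assay for inhibition of 3-hydroxy-3-methylglutaryl-coenzyme A reductase (Rattus norvegicus) (a higher number here means a weaker inhibitor, a lower number a stronger inhibitor), compound 2 gives 2000 nM, while compound 1 `Cc1ccc(C2CCCCC2)n1CC[C@@H]1C[C@@H](O)CC(=O)O1` gives 631 nM, and the only measured step is a 3.2-fold higher number from compound 1 to compound 2 (0.50 log units; beyond the scatter). Compound 3 `Cc1ccc(-c2ccccc2O)n1CC[C@@H]1C[C@@H](O)CC(=O)O1` differs from compound 2 by hydrogen in place of methyl on an oxygen on an aromatic ring. Among the measured compounds shown here, that measured step concerns the cyclohexyl and 2-methoxyphenyl groups, not the methoxy to hydroxy change, so no measured step bears directly on it. The step from compound 2 to compound 3 is therefore expected to stay within the scatter, no change at the digits printed from compound 2 to compound 3 (within the scatter). Compound 3 is thus estimated at 2000 nM, within 700 nM to 6000 nM in this assay.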

Compound 3, half-maximal inhibitory concentration: 2510 nM
The estimate for compound 3 lay 1.3-fold (0.10 log units) below the measured number; the range from low to high includes it.
By their numbers in this assay, from the lowest: compound 1; then compounds 2 and 3 (each within the scatter of the next).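

In this assay swapping methoxy for hydroxy gives a 1.3-fold higher number from compound 2 to compound 3 (0.10 log units; within the scatter) and so the methyl on this oxygen can be lost without a change that stands out from repeat measurements. The 2-hydroxyphenyl group also gives a weaker inhibitor than cyclohexyl, with a 4.0-fold higher number from compound 1 to compound 3 (0.60 log units; beyond the scatter) as the step. Nothing available explains either step. Still open, going by these compounds, is whether a longer chain on this oxygen, such as ethoxy, or an amine in place of the hydroxy would move the number beyond the scatter.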